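The source may report more compounds than this note shows. Statements on the series, on what has been measured and on what is new or still open speak of the compounds shown alone.

Values in a functional assay on HUVEC cells (Homo sapiens), read by scintillation counting and thymidine incorporation, with a stated time of 24 h; on this read-out higher numbers stand for weaker inhibition and lower numbers for stronger inhibition:
- compound 1 `CCC(C)n1ncn(-c2ccc(N3CCN(c4ccc(OC[C@@H]5CO[C@@](CN6CCNCC6)(c6ccc(Cl)cc6Cl)O5)cc4)CC3)cc2)c1=O` gives 608 nM
- compound 2 `CCC(C)n1ncn(-c2ccc(N3CCN(c4ccc(OC[C@@H]5CO[C@@](Cn6ccnc6C(C)C)(c6ccc(Cl)cc6Cl)O5)cc4)CC3)cc2)c1=O` gives 84 nM

Of the two measured compounds, compound 2 has the lower number, at 84 nM, and so stands lowest so far. Compound 3 `CCC(C)n1ncn(-c2ccc(N3CCN(c4ccc(OC[C@@H]5CO[C@@](Cn6cnnn6)(c6ccc(Cl)cc6Cl)O5)cc4)CC3)cc2)c1=O` has 1H-tetrazol-1-yl in place of 2-isopropyl-1H-imidazol-1-yl on a saturated chain carbon bound to a saturated ring carbon. Among the compounds with values here, one measured step bears on this place, a 7.2-fold lower number from compound 1 to compound 2 (0.86 log units; beyond the scatter), a modest change beyond the scatter. Within the data shown here, no measured compound carries the entering group, so this step gives a size but no firm direction. In this assay, among the measured compounds shown here, a modest rise in the number is expected, probably no larger than that step. The expected step is a 2.4-fold higher number from compound 2 to compound 3 (0.38 log units; beyond the scatter). For compound 3 the estimated value is 200 nM, with an expected range from 70 nM to 600 nM.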

Compound 3, half-maximal inhibitory concentration: 73 nM
For compound 3 the middle estimate is 2.7-fold (0.44 log units) above the measured one, within the range that was stated.
By their numbers in this assay, from the lowest: compounds 3 and 2 (each within the scatter of the next); then compound 1.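

At the position on a saturated chain carbon bound to a saturated ring carbon, 2-isopropyl-1H-imidazol-1-yl and 1H-tetrazol-1-yl cannot be told apart in this assay: the data show a 1.2-fold lower number from compound 2 to compound 3 (0.06 log units; within the scatter) even though the entering group has fewer heavy atoms and more hydrogen-bond acceptors. The data also show an 8.3-fold lower number from compound 1 to compound 3 (0.92 log units; beyond the scatter) so both five-membered aromatic rings shown stand apart from piperazin-1-yl, and the isopropyl group of compound 2 is not required for this difference. Nothing at hand gives a reason for these numbers.

Open, going by these compounds, is whether the aromatic ring itself is required at this position, which a simple dimethylamino group or a carboxylic acid on the same chain carbon would test. Also open is how unsubstituted 1H-imidazol-1-yl would compare with the two rings shown.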